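Butyl at the methoxy-bearing carbon of a pyridine-tetrazole amide series

The source may report more compounds than this note shows. Statements on the series, on what has been measured and on what is new or still open speak of the compounds shown alone.

Measured compounds:
compound 1 `COc1cc(C(=O)Nc2nn[nH]n2)nc(-c2ccccc2)c1`: 97%
compound 2 `O=C(Nc1nn[nH]n1)c1cccc(-c2ccccc2)n1`: 74%
compound 3 `Nc1ccc(-c2cccc(C(=O)Nc3nn[nH]n3)n2)cc1`: 81%

In a functional assay on the whole organism with Rattus norvegicus as the target, at a dose of 3 mg/kg by the oral route (a higher number here means a stronger effect of the compound at the dose given, a lower number a weaker effect), compound 1 gives 97%, compound 2 gives 74% and compound 3 gives 81%. Compound 2 stands lowest of the three numbers; compound 3 lies closest to it, by a number 7 percentage points higher from compound 2 to compound 3 (within the scatter), and compound 1 lies furthest, since a number 23 percentage points lower from compound 1 to compound 2 (beyond the scatter).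

Compound 4 `CCCCc1cc(C(=O)Nc2nn[nH]n2)nc(-c2ccccc2)c1` is not yet measured. Compared with compound 2 the change is butyl in place of hydrogen on an aromatic carbon; the entering group is a chain, without a ring and with no hydrogen-bond donors or acceptors.

For the measured compounds named here, only one measured step bears on this site: a number 23 percentage points lower from compound 1 to compound 2 (beyond the scatter), where methoxy gave way to hydrogen on the same aromatic carbon, a modest loss beyond the scatter. Butyl is not methoxy, so the size is uncertain, but a gain in this assay is expected rather than a loss. Compound 4 is expected to show a number 14 percentage points higher from compound 2 to compound 4 (beyond the scatter), giving an estimated 88%, within a range of 70% to 99%.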

Compound 4, a percentage reported as inhibition, in the whole organism at one dose (the size of the read-out at that dose, not a potency): 71%
Estimate against measurement, compound 4: 17 percentage points above; the measured number falls inside the stated range.
By their numbers in this assay, from the lowest: compounds 4, 2 and 3 (each within the scatter of the next); then compound 1.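

In this assay butyl opposite the ring nitrogen gives a number 3 percentage points lower from compound 2 to compound 4 (within the scatter) and so does not separate from hydrogen at this carbon. Butyl in place of methoxy gives a number 26 percentage points lower from compound 1 to compound 4 (beyond the scatter) and shows that the higher number of compound 1 is not shared by every substituent here: at this position it goes with methoxy and does not extend to this chain. Nothing measured in the data at hand explains why methoxy and butyl part at this carbon.

Open, on these data alone, is whether ethoxy, hydroxyl or an amine at this carbon would follow methoxy or butyl, and whether a shorter chain such as methyl would read like butyl. Also open, as far as these compounds go, is whether methoxy would keep its step on a core that carries the amino group of compound 3 on the phenyl ring.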